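The compounds below may be only part of what the source reports. "The series", "measured", "known", "first", "only" and "open" are said of these compounds alone.

Working notes on the series. Compound 1 `O=c1[nH]c(=O)n(COCCO)cc1[N+](=O)[O-]` and compound 2 `Nc1ccn(COCCO)c(=O)n1` share the (2-hydroxyethoxy)methyl chain and have been tested in a functional assay (Oryctolagus cuniculus) for inhibition; a lower number here means a stronger inhibitor, a higher number a weaker inhibitor. Compound 1 gives only a limit of the assay in this assay, > 400 ug/mL. Compound 2 likewise gives only a limit in this assay, > 400 ug/mL. Compound 2 therefore stands at the limit of > 400 ug/mL in this assay, at which 2 of the 2 values shown sit. Compound 3 `Nc1nc(=O)n(COCCO)cc1[N+](=O)[O-]` follows from compound 2 by nitro in place of hydrogen on an aromatic carbon. For the measured compounds named here, no measured step guides the size of this change. Compound 1, which also carries the nitro group, sits at the limit. No shift beyond the scatter in this assay is expected, and the step of a number no higher from compound 2 to compound 3 (the limit leaves the size open) is expected to be small. Compound 3 is expected to give about 400 ug/mL in this assay, within 150 ug/mL to 1000 ug/mL, most likely again as a limit.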

Compound 3, concentration for 50% inhibition: > 400 ug/mL
Compound 3 gave a limit, no number; the forecaster's own chance of this, stated with the estimate: 80%; the middle value lies on the limit itself.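

Compound 2 and compound 3 both give only limits in this assay, so no step can be read between them. The compounds shown leave open how strongly any of them inhibits: the limit of > 400 ug/mL in this assay, at which 3 of the 3 values shown sit.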